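Fluorine on the core of a slowly cleared sulfone

This account rests on a few compounds, and the source may have more. Where it says the series, first, only, none or still open, it means among the compounds named here.

Three compounds have been measured in an ADME assay on microsomes from liver (Homo sapiens) for metabolic stability, tested at 2.5 uM; a higher number here means faster removal of the compound, a lower number slower removal:

compound 1, `COc1ccc(-c2c(S(=O)(=O)c3ccc(F)cc3)cnc3cc(F)ccc23)cc1`: 1.77 mL/min
compound 2, `O=S(=O)(c1ccc(F)cc1)c1cnc2ccc(Cl)cc2c1-c1ccc(Cl)cc1`: 0.01 mL/min
compound 3, `COc1ccc(-c2c(S(=O)(=O)c3ccc(F)c(F)c3)cnc3cc(F)ccc23)cc1`: 1.1 mL/min

Compound 1 and compound 3 share one core and differ only by fluoro in place of hydrogen on an aromatic carbon. In this assay that change gave a 1.6-fold lower number from compound 1 to compound 3 (0.21 log units; within the scatter). Compound 2 is built on another core; the difference between the two cores is not broken down here. Its number is the lowest of the three, and its distance from each of the other two lies beyond the scatter.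

Compound 4, `O=S(=O)(c1ccc(F)cc1)c1cnc2c(F)cc(Cl)cc2c1-c1ccc(Cl)cc1`, has not been measured. It differs from compound 2 by fluoro in place of hydrogen on an aromatic carbon. For the measured compounds named here, this is the same kind of change as the one from compound 1 to compound 3, but not the same: there the fluoro sits ortho to a fluoro group and meta to a large group, here it sits on a ring that is part of a fused or bridged system of two rings, ortho to a fused ring and meta to a chloro group.

From compound 2 to compound 4 the step in this assay is expected to be no change at the digits printed from compound 2 to compound 4 (within the scatter), because the same kind of change gave only a 1.6-fold lower number from compound 1 to compound 3 (0.21 log units; within the scatter). Compound 4 is therefore expected to give about 0.01 mL/min, most likely between 0.003 mL/min and 0.04 mL/min.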

Compound 4, intrinsic clearance in a liver preparation (reported as CLH), per the amount of preparation that the assay uses: 0.01 mL/min
The estimate for compound 4 equals the measured number at the digits printed; the measured number falls inside the stated range.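

In this assay, fluoro in place of hydrogen on an aromatic carbon gave no change at the digits printed from compound 2 to compound 4 (within the scatter). Set beside the earlier step, the same kind of change looks alike on the two cores, with neither step standing out from the other: the same change on two cores in this assay, a 1.6-fold lower number (0.21 log units; within the scatter) from compound 1 to compound 3 and no change at the digits printed (within the scatter) from compound 2 to compound 4, 1.6-fold (0.21 log units) apart, within the scatter of two such steps. This shows only that the change left the number within the scatter in both of these cases; it does not show that the result would hold on other cores, since the fluoro sits at a different kind of place in each case and only two cores are shown.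

The compounds shown leave open whether fluoro at other aromatic carbons of these cores would behave the same way. They also leave open whether a different group on the same aromatic carbon of compound 2, such as an amine or a carboxylic acid, would shift the number in this assay.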